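The compounds below may be only part of what the source reports. "The series", "measured", "known", "first", "only" and "open" are said of these compounds alone.

For the measured compounds named here, in an ADME assay on MT4 cells (Homo sapiens) for cytotoxicity (on this read-out higher numbers stand for lower toxicity in this test and lower numbers for higher toxicity in this test), compound 1 `N#Cc1ccc(NC(=S)Nc2cccc(C(F)(F)F)c2)cc1` gives 7000 nM, the only true number so far. For compound 2 `CCNC(=S)Nc1cccc(C(F)(F)F)c1` the result is only a limit (> 100000 nM) and not a number.

Compound 3 `Fc1cccc(NC(=S)Nc2cccc(C(F)(F)F)c2)c1` differs from compound 2 in one place: 3-fluorophenyl stands in place of ethyl on an amide-type nitrogen (3-fluorophenyl in place of ethyl on an amide-type nitrogen). Going by the values given here, no measured step is available to size this change directly. The expectation therefore leans on compound 1 alone, which also holds a six-membered aromatic ring of carbon only on an amide-type nitrogen and gives 7000 nM in this assay as the nearest guide. Compound 3 is thus expected to land at clearly lower numbers than the limit of compound 2, which would mean higher toxicity in this test. The expected change is an at least 10-fold lower number from compound 2 to compound 3 (1.00 log units; beyond the scatter) and would lie beyond the usual scatter. Compound 3 is estimated at 10000 nM with an expected range from 3000 nM to 40000 nM in this read-out.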

Compound 3, half-maximal cytotoxic concentration: 20000 nM
Compound 3: middle estimate off by 2.0-fold (0.30 log units), on the low side; measured number inside the range.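

In this assay, putting 3-fluorophenyl in place of ethyl on an amide-type nitrogen gives an at least 5.0-fold lower number from compound 2 to compound 3 (0.69 log units; beyond the scatter), the first measured size for a change at this position. For the compounds shown here, until now, compound 1 was the only compound here with a true number, and compound 3 at 20000 nM now shows that a second group with a six-membered aromatic ring of carbon only at this place also gives a value that can be read as a number. The step gives only the least size of the change because compound 2 stands at a limit and not at a number: the limit of > 100000 nM in this assay, at which 1 of the 3 values shown sits.

From the compounds shown here alone, how much of the lower number belongs to the ring itself and how much to the fluorine it carries stays open, and a plain phenyl group on the same nitrogen would help to separate the two. Going by these compounds, it is also open whether a longer chain such as butyl in place of ethyl would keep the read-out at a limit or bring it into the range where compound 1 and compound 3 give true numbers.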